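This account rests on a few compounds, and the source may have more. Where it says the series, first, only, none or still open, it means among the compounds named here.

Measured compounds in a functional assay on SK-MEL-5 cells (Homo sapiens) for inhibition, read by sulforhodamine B assay, with a stated time of 48 h; on this read-out lower numbers stand for stronger inhibition of growth and higher numbers for weaker inhibition of growth: compound 1 `COc1ccc(CNc2nc3cc(N)cc(N)c3nc2-c2ccccc2)cc1OC` at 27500 nM; compound 2 `CCOC(=O)[C@H](CCC(=O)O)NC(=O)c1ccc(Sc2nc3cc(N)cc(N)c3nc2-c2ccccc2)cc1` at 32400 nM; compound 3 `COc1cc(CNc2nc3cc(N)cc(N)c3nc2-c2ccccc2)cc(OC)c1OC` at 7760 nM.

Compound 1 holds the second highest of these three numbers. Compound 2 sits nearest, within the scatter, so no order between the two can be read. Compound 3 lies furthest, reached by a 3.5-fold lower number from compound 1 to compound 3 (0.55 log units; beyond the scatter), a change that added a methoxy on an aromatic carbon.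

Compound 4 `COc1ccc(CNc2nc3cc(N)cc(N)c3nc2-c2ccccc2)cc1` goes the other way from compound 1: hydrogen in place of methoxy on an aromatic carbon, which reads 3,4-dimethoxyphenyl to 4-methoxyphenyl. Within the data shown here, the only step that bears on this is the one from compound 1 to compound 3, where adding a methoxy lowered the number modestly; removing one is therefore expected to raise it, modestly, in this assay. For compound 4 the estimate is 45000 nM, between 15000 nM and 130000 nM, a step of a 1.6-fold higher number from compound 1 to compound 4 (0.21 log units; within the scatter).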

Compound 4, concentration for total growth inhibition: 31600 nM
Compound 4: the middle estimate sits 1.4-fold (0.15 log units) above what was measured; the measured number falls inside the stated range.
By their numbers in this assay, from the lowest: compound 3; then compounds 1, 4 and 2 (each within the scatter of the next).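

Taking the methoxy off this aromatic carbon, ortho to a methoxy group, gives a 1.1-fold higher number from compound 1 to compound 4 (0.06 log units; within the scatter) and so shows no readable change in this assay. The earlier methoxy step, a 3.5-fold lower number from compound 1 to compound 3 (0.55 log units; beyond the scatter), did go beyond the scatter, so methoxy changes on this ring do not all move the number alike. Nothing available here accounts for that difference. From the compounds shown here alone, whether an amine, a hydroxyl or a carboxylic acid on this same carbon would also leave the number in place remains open.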